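The source may hold more compounds than are shown below. What is called first, only, known or untested is meant among the compounds shown, and "the series" means these compounds.

Measured so far:

compound 1: `CCCCOc1ccc(C(C)=O)cc1CSc1nc2cc(F)ccc2n1CC(=O)O`, 12 nM

compound 2: `COc1ccc(C(=O)c2ccccc2)cc1CSc1nc2cc(F)ccc2n1CC(=O)O`, 4 nM

In a functional assay on HEK293 cells for antagonist activity at prostaglandin D2 receptor 2 (Homo sapiens), read by FLIPR and calcium flux (on this read-out higher numbers stand for weaker inhibition and lower numbers for stronger inhibition), compound 1 gives 12 nM, and compound 2 gives 4 nM. Compound 2 holds the lower of the two numbers, and its gap to compound 1 lies beyond the usual scatter of repeated measurements, so on these two numbers alone compound 2 is the stronger inhibitor. Among the compounds with values here, the two compounds differ at more than one place, so no single step between them can be read off.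

Compound 3, `COc1ccc(C(=O)NCc2ccccc2)cc1CSc1nc2cc(F)ccc2n1CC(=O)O`, is not yet measured. It differs from compound 2 in a single place: benzylamino in place of phenyl on a carbonyl carbon. Within the data shown here, no pair of measured compounds shows a change of this kind, so nothing here tells how such a change moves the number; the expectation for compound 3 rests on the value of compound 2 in this assay, 4 nM. For compound 3 the expected step of a 2.5-fold higher number from compound 2 to compound 3 (0.40 log units; beyond the scatter) is a small loss, one that may stay within the scatter. The estimate for compound 3 is 10 nM, with a range from 3 nM to 40 nM.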

Compound 3, half-maximal inhibitory concentration: 94 nM
Compound 3: middle estimate off by 9.4-fold (0.97 log units), on the low side; the measured number lies above the stated range.
By their numbers in this assay, from the lowest: compound 2; then compound 1; then compound 3.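

In this assay, putting benzylamino in place of phenyl on a carbonyl carbon, so that benzoyl becomes benzylcarbamoyl, gives a 24-fold higher number from compound 2 to compound 3 (1.37 log units; beyond the scatter), a large loss of inhibition. The entering group still holds one six-membered aromatic ring of carbon only, so the presence of such a ring on this carbonyl carbon does not by itself keep the number low; the change also adds a nitrogen, a hydrogen-bond donor and one more carbon. No measurement shown here explains which of these differences accounts for the loss.

The compounds shown leave open whether the loss follows the nitrogen or the longer link to the ring: phenylamino, which keeps the nitrogen without the extra carbon, and benzyl, which keeps the extra carbon without the nitrogen, would separate the two if placed on the same carbonyl carbon. Also open, from the compounds shown here alone, is whether a ring is needed on this carbonyl carbon at all, since methyl stands there only in compound 1, which differs from compound 2 at more than one place, so that step cannot be read.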